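The source may hold more compounds than are shown below. What is called first, only, known or untested is meant among the compounds shown, and "the series" means these compounds.

Of the compounds shown here, three have been tested in an ADME assay on HEK-293T cells (Homo sapiens) for cytotoxicity, read by CCK-8 assay, with a stated time of 48 h; on this read-out lower numbers stand for stronger inhibition and higher numbers for weaker inhibition. Compound 1 `O=[N+]([O-])c1ccc(NC(=S)NCCNS(=O)(=O)c2ccc(-c3ccccc3O[C@H]3CC[C@@H](O)CC3)s2)cc1` gives 20000 nM. Compound 3 `O=[N+]([O-])c1ccc(NC(=S)NCCNS(=O)(=O)c2ccc(-c3ccccc3OCc3ccccc3)s2)cc1` gives 8900 nM. Compound 2 `O=C(NCCNS(=O)(=O)c1ccc(-c2ccccc2Oc2ccc(O)c(O)c2)s1)Nc1cc(Cl)cc(Cl)c1` gives 12400 nM, the second highest of the three numbers; its gaps to compound 1 and to compound 3 both lie within the scatter. Within the data shown here, the only single change measured is a 2.2-fold lower number from compound 1 to compound 3 (0.35 log units; beyond the scatter), a benzyl in place of a 4-hydroxycyclohexyl on an oxygen on an aromatic ring.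

Compound 4 `O=C(NCCNS(=O)(=O)c1ccc(-c2ccccc2Oc2ccc([N+](=O)[O-])c([N+](=O)[O-])c2)s1)Nc1cc(Cl)cc(Cl)c1` differs from compound 2 in one place: 3,4-dinitrophenyl in place of 3,4-dihydroxyphenyl on an oxygen on an aromatic ring. Among the measured compounds shown here, no measured step touches this exchange; the one step known concerns a different group on a different core, so it gives no direct guide. All three measured numbers sit in a narrow band, and nothing in them points to a large move in either direction. The change is therefore expected to produce no step beyond the scatter: a 1.0-fold lower number from compound 2 to compound 4 (0.01 log units; within the scatter). Compound 4 is estimated at 12000 nM, with a range from 5000 nM to 30000 nM.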

Compound 4, half-maximal inhibitory concentration: > 20000 nM
Compound 4: only a limit was reported; the forecaster's own chance of this, stated with the estimate: 25%; at least 1.6-fold (0.22 log units) between middle value and limit.
By their numbers in this assay, from the lowest: compounds 3, 2 and 1 (each within the scatter of the next, the first and the last beyond it).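

Among these compounds, this position on the core of compound 2, the group on an oxygen on an aromatic ring, is probed here for the first time: in this assay, 3,4-dinitrophenyl in place of 3,4-dihydroxyphenyl gives an at least 1.6-fold higher number from compound 2 to compound 4 (0.20 log units; that floor lies within the scatter). Compound 4 has no exact number, only a limit of the assay: the limit of > 20000 nM in this assay, at which 1 of the 4 values shown sits. The exchange therefore shows no sign of a lower number at this position, but the floor of the step does not establish a rise either.

From the compounds shown here alone, how far the true value of compound 4 lies from that limit stays open, so the full size of the step is unknown. Also open, going by these compounds, is how an amine or a carboxylic acid on this phenyl ring would read, and whether the same exchange would behave alike on the core of compound 3.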